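The compounds below may be only part of what the source reports. "The series", "measured", "known", "first", "only" and "open" are said of these compounds alone.

Two compounds share one core. Compound 1 is `CS(=O)(=O)Nc1ccc2c(c1)S(=O)(=O)C=C(c1c(O)c3ccccc3n(Cc3ccc(F)cc3)c1=O)N2`. In an ADME assay on 2209-23 cells (Homo sapiens) for cytotoxicity, read by WST assay (on this read-out higher numbers stand for lower toxicity in this test and lower numbers for higher toxicity in this test), compound 1 reaches only the limit of the measurement, at > 50000 nM. Compound 2 is `Cc1ccc2c(c1)c(O)c(C1=CS(=O)(=O)c3cc(NS(C)(=O)=O)ccc3N1)c(=O)n2Cc1ccc(F)cc1`, which carries a methyl in place of hydrogen on an aromatic carbon of that core. In this assay compound 2 likewise shows only a limit, at > 50000 nM. Among the measured compounds shown here, because of this the single measured step, a step that the two limits leave unreadable from compound 1 to compound 2, cannot be read: both ends sit at the limit, as summed up by the limit of > 50000 nM in this assay, at which 2 of the 2 values shown sit, so no number tells how large the step is or in which direction it runs.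

Compound 3 is `COc1ccc2c(c1)c(O)c(C1=CS(=O)(=O)c3cc(NS(C)(=O)=O)ccc3N1)c(=O)n2Cc1ccc(F)cc1`. It differs from compound 2 by methoxy in place of methyl on an aromatic carbon. For the measured compounds named here, the only step that bears on this change is the unreadable one from compound 1 to compound 2, so there is no measured size to lean on. Given that compound 2 sits at the limit, the change is expected to be small, as a step that the limit leaves unreadable from compound 2 to compound 3, with compound 3 most likely also beyond the limit. The estimate for compound 3 in this assay is 80000 nM, between 30000 nM and 300000 nM.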

Compound 3, half-maximal cytotoxic concentration: > 50000 nM
Compound 3: a limit, no number (the forecaster's own chance of this, stated with the estimate: 85%); the middle value lies beyond the limit too.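

Compound 3 also reaches only a limit in this assay. The steps to compound 3 from compound 1 and from compound 2 cannot be read, because all the compounds shown sit at one limit: the limit of > 50000 nM in this assay, at which 3 of the 3 values shown sit.

The compounds shown leave open whether methyl or methoxy on that aromatic carbon changes the cytotoxic concentration at all, and in which direction.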